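The source may report more compounds than this note shows. Statements on the series, on what has been measured and on what is new or still open speak of the compounds shown alone.

Measured so far:
- compound 1, `CCCCCCCCCCCCOc1ncnc2c1ncn2CC(=O)OCC`: > 10 ug/mL in an ADME assay on Vero cells (Chlorocebus sabaeus) for cytotoxicity; on this read-out lower numbers stand for higher toxicity in this test and higher numbers for lower toxicity in this test
- compound 2, `CCCCCCCCCCCCOc1nc(N)nc2c1ncn2CC(=O)OCC`: > 10 ug/mL in this assay

Both values are limits of the assay rather than numbers. In this assay compound 1 gives only a limit, > 10 ug/mL. Compound 2 likewise gives only a limit, > 10 ug/mL, in this assay. Among the measured compounds shown here, the one measured step, amino in place of hydrogen on an aromatic carbon, is therefore a step that the two limits leave unreadable from compound 1 to compound 2; both values sit at the limit of > 10 ug/mL in this assay, at which 2 of the 2 values shown sit, so the step's size cannot be read.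

Compound 3, `CCCCCCCCCCOc1ncnc2c1ncn2CC(=O)OCC`, is not yet measured. It differs from compound 1 by hydrogen in place of ethyl on a saturated chain carbon, ten or more bonds along the chain from an oxygen on an aromatic ring. The measured step concerns a different part of the shared core and shows nothing readable, so there is no evidence either way on the effect of shortening the chain. Given that compound 1 stands only at its limit, the expected step is a step that the limit leaves unreadable from compound 1 to compound 3, with no readable change anticipated. Compound 3 is thus estimated at 20 ug/mL, in the range 8 ug/mL to 50 ug/mL, most likely again reported as a limit in this assay.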

Compound 3, half-maximal cytotoxic concentration: > 62.5 ug/mL
Compound 3 ended at the assay's limit; the forecaster's own chance of this, stated with the estimate: 80%; middle value at least 3.1-fold (0.49 log units) away from the limit.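

Compound 1 and compound 3 are each reported in this assay only as a limit, so the change from one to the other has no size that can be read. The compounds shown leave open where the actual half-maximal cytotoxic concentrations lie, and so whether shortening the chain or adding the amino group changes this read-out at all.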